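The compounds below may be only part of what the source reports. "The series", "measured", "known", "first", "only" and "open" are said of these compounds alone.

Among the compounds with values here, in an ADME assay on HepG2 cells (Homo sapiens) for cytotoxicity, with a stated time of 72 h (a higher number here means that more compound is needed for the effect, a lower number that less compound is needed), compound 2 `COC(=O)c1cccc(NC(=O)Nc2cc(C)nc3ccccc23)c1` gives 23000 nM, the only actual number so far. Compound 1 `Cc1cc(NC(=O)Nc2cccc(C(N)=O)c2)c2ccccc2n1` gives a limit and no number: > 25000 nM. The evidence from this pair therefore amounts to the limit of > 25000 nM in this assay, at which 1 of the 2 values shown sits. Within the data shown here, the one measured step, an at least 1.0-fold lower number from compound 1 to compound 2 (0.03 log units; that floor lies within the scatter), puts methoxy in place of amino on a carbonyl carbon, and it does not go beyond the scatter. Compound 3 `Cc1cc(NC(=O)Nc2cccc(C(F)(F)F)c2)c2ccccc2n1` carries a different change: trifluoromethyl in place of methoxycarbonyl on an aromatic carbon, meta to a large group (trifluoromethyl in place of methoxycarbonyl on an aromatic carbon). Among the measured compounds shown here, no measured step replaces this group, so compound 1 and compound 2 offer only a loose guide. The expected step, a 1.6-fold lower number from compound 2 to compound 3 (0.22 log units; within the scatter), is toward a somewhat lower number in this assay, but not clearly beyond the scatter. For compound 3 the estimate is 14000 nM, with an expected range from 5000 nM to 25000 nM.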

Compound 3, half-maximal effective concentration: 21000 nM
The estimate for compound 3 lay 1.5-fold (0.18 log units) below the measured number, and the stated range covers the measured number.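

In this assay, trifluoromethyl in place of methoxycarbonyl on this aromatic carbon, meta to a large group, gives a 1.1-fold lower number from compound 2 to compound 3 (0.04 log units; within the scatter). This shows that a group with no hydrogen-bond acceptors can stand here without moving the number beyond the scatter, which the earlier pair, both carrying a carbonyl at this position, could not show. Trifluoromethyl in place of carbamoyl gives an at least 1.1-fold lower number from compound 1 to compound 3 (0.07 log units; that floor lies within the scatter), which is only a floor, so the size of that step stays unknown, and the comparison with compound 1 rests on a limit and not a number: the limit of > 25000 nM in this assay, at which 1 of the 3 values shown sits.

Going by these compounds, whether an amine, a carboxylic acid or a longer chain at this position would shift the number beyond the scatter remains open. Also open, on these data alone, is whether a change elsewhere on the shared core would do so.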